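The source may report more compounds than this note shows. Statements on the series, on what has been measured and on what is new or still open speak of the compounds shown alone.

Working notes on the series in an ADME assay on TERT-RPE1 cells (Homo sapiens) for cytotoxicity, read by resazurin assay, with a stated time of 48 h; on this read-out lower numbers stand for stronger inhibition and higher numbers for weaker inhibition.

Compound 1 `CCOc1ccc(-n2nnc3n[nH]c(NC)c3c2=O)cc1` and compound 2 `CCOc1ccc(-n2nnc3n[nH]c(Nc4ccccc4)c3c2=O)cc1` share one core. In this assay compound 1 returns only a limit of the assay, > 100000 nM. In this assay compound 2 likewise returns only a limit, > 100000 nM. The change from compound 2 to compound 1 is methyl in place of phenyl on a nitrogen on an aromatic ring, and the step that the two limits leave unreadable from compound 2 to compound 1 cannot be read in size, since both ends are limits.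

Compound 3 `CCOc1ccc(NC(=O)/C(C#N)=C(\Nc2ccccc2)SC)cc1` carries a different core; how the core of compound 3 differs from that of compound 2 is not broken down here. In this assay compound 3 again returns only a limit, > 100000 nM. Compound 4 `CCOc1ccc(NC(=O)/C(C#N)=C(\NC)SC)cc1` is not yet measured. It differs from compound 3 by methyl in place of phenyl on an amine nitrogen. The place is not the same as in the earlier pair: there the nitrogen sits on an aromatic ring with an aromatic carbon as its other neighbour, here it is an amine nitrogen whose other neighbour is a double-bonded chain carbon, so the two changes are the same kind of change, not the same.

The expectation for the step from compound 3 to compound 4 rests on (the limit of > 100000 nM in this assay, at which 3 of the 3 values shown sit), so the step that the limit leaves unreadable from compound 3 to compound 4 is expected to stay unreadable, as a step that the two limits leave unreadable from compound 2 to compound 1 was. For compound 4 in this assay the expected value is 150000 nM, with a range from 60000 nM to 400000 nM, most likely reported as a limit only.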

Compound 4, half-maximal inhibitory concentration: > 100000 nM
Compound 4: no number, only a limit; the forecaster's own chance of this, stated with the estimate: 85%; the middle value is on the limit's open side.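

Compound 4, like compound 3, returns only a limit in this assay, so no step between compound 3 and compound 4 can be read in size: the limit of > 100000 nM in this assay, at which 4 of the 4 values shown sit.

The compounds shown leave open how far any of these structures lies from a measurable half-maximal inhibitory concentration in this assay, and whether exchanging phenyl for methyl on the nitrogen changes it at all.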